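The source may report more compounds than this note shows. Statements on the series, on what has been measured and on what is new or still open speak of the compounds shown alone.

Compound 1 `COc1cc(-c2nn(-c3ccc(NC(=O)c4ccc(Cl)c(Cl)c4)cc3)cc2-c2ccncc2)ccc1Cl` is the starting point. In a functional assay on SK-MEL-5 cells (Homo sapiens) for antiproliferative activity, read by sulforhodamine B assay, with a stated time of 48 h (on this read-out lower numbers stand for stronger inhibition and higher numbers for weaker inhibition), compound 1 gives 1650 nM. Compound 2 `COc1cc(-c2nn(-c3ccc(NC(=O)c4cc(Cl)cc(Cl)c4)cc3)cc2-c2ccncc2)ccc1Cl` differs from it only by 3,5-dichlorophenyl in place of 3,4-dichlorophenyl on a carbonyl carbon, and in this assay compound 2 gives 12000 nM, so the swap costs a 7.3-fold higher number from compound 1 to compound 2 (0.86 log units; beyond the scatter).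

Compound 3 `O=C(Nc1ccc(-n2cc(-c3ccncc3)c(-c3ccc(Cl)c(O)c3)n2)cc1)c1ccc(Cl)c(Cl)c1` carries a different core: it differs from compound 1 by hydrogen in place of methyl on an oxygen on an aromatic ring, a step of a 1.4-fold lower number from compound 1 to compound 3 (0.16 log units; within the scatter). In this assay compound 3 gives 1150 nM.

Compound 4 `O=C(Nc1ccc(-n2cc(-c3ccncc3)c(-c3ccc(Cl)c(O)c3)n2)cc1)c1cc(Cl)cc(Cl)c1` has not yet been measured. It differs from compound 3 by 3,5-dichlorophenyl in place of 3,4-dichlorophenyl on a carbonyl carbon, and the place of the change is the same, word for word, as in the change from compound 1 to compound 2. Because the earlier swap gave a 7.3-fold higher number from compound 1 to compound 2 (0.86 log units; beyond the scatter), the step from compound 3 to compound 4 is expected to be of similar size, a 6.1-fold higher number from compound 3 to compound 4 (0.78 log units; beyond the scatter). Compound 4 is therefore estimated at 7000 nM, most likely between 3000 nM and 17000 nM.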

Compound 4, half-maximal inhibitory concentration: 1400 nM
For compound 4 the middle estimate is 5.0-fold (0.70 log units) above the measured one; the measured number lies below the stated range.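

On the core of compound 3, the swap to 3,5-dichlorophenyl gives a 1.2-fold higher number from compound 3 to compound 4 (0.09 log units; within the scatter), so in this assay the size of this step does not carry over from one core to the other: the same change on two cores in this assay, a 7.3-fold higher number (0.86 log units; beyond the scatter) from compound 1 to compound 2 and a 1.2-fold higher number (0.09 log units; within the scatter) from compound 3 to compound 4, 6.0-fold (0.78 log units) apart, beyond the scatter of two such steps. Hydrogen in place of methyl on the oxygen also changes in size with the dichlorophenyl group present, giving an 8.6-fold lower number from compound 2 to compound 4 (0.93 log units; beyond the scatter) against the earlier step: the same change on two cores in this assay, a 1.4-fold lower number (0.16 log units; within the scatter) from compound 1 to compound 3 and an 8.6-fold lower number (0.93 log units; beyond the scatter) from compound 2 to compound 4, 6.0-fold (0.78 log units) apart, beyond the scatter of two such steps. Both gaps come from the same four compounds, so they form a single observation, and it shows neither why the steps differ nor how either change would behave on any other core.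

Still open, from the compounds shown here alone, is whether the same mismatch appears with an unsubstituted phenyl on the carbonyl carbon. Also open, going by these compounds, is what an ethyl in place of the methyl on the oxygen would do.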